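This account rests on a few compounds, and the source may have more. Where it says the series, first, only, none or still open, it means among the compounds named here.

Compound 1 `COc1cc(Cl)cc(-c2nn(-c3cccc(NC(=O)Nc4ccc(Cl)c(C(F)(F)F)c4)c3)cc2-c2ccncc2)c1`: -4.76%
Compound 2 `COc1cc(Cl)cc(-c2nn(-c3cccc(NC(=O)Nc4cc(C(F)(F)F)cc(C(F)(F)F)c4)c3)cc2-c2ccncc2)c1`: -26.9%
Compound 3 `COc1cc(Cl)cc(-c2nn(-c3cccc(NC(=O)Nc4ccc(Cl)c(Cl)c4)c3)cc2-c2ccncc2)c1`: 19.6%

These three compounds share one core and differ only in the aryl group attached to an amide-type nitrogen. In a functional assay on 786-0 cells (Homo sapiens) for inhibition, read by sulforhodamine B assay, with a stated time of 48 h, tested at 10 uM (on this read-out lower numbers stand for a stronger effect and higher numbers for a weaker effect at the one concentration tested), compound 3 gives 19.6%, the highest of the three numbers and so the weakest effect; compound 1 gives -4.76% and compound 2 gives -26.9%. Going by the values given here, the single measured step between neighbours, a number 24.4 percentage points higher from compound 1 to compound 3 (beyond the scatter), is modest but beyond the scatter.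

Compound 4 `COc1cc(Cl)cc(-c2nn(-c3cccc(NC(=O)Nc4cccc(C(F)(F)F)c4)c3)cc2-c2ccncc2)c1` has not yet been measured. It differs from compound 3 by 3-(trifluoromethyl)phenyl in place of 3,4-dichlorophenyl on an amide-type nitrogen. Among the compounds with values here, the one measured step that bears on this is a number 24.4 percentage points higher from compound 1 to compound 3 (beyond the scatter), where a chloro replaced a trifluoromethyl and the number rose. The present change runs the other way, a chloro-bearing group leaving and a trifluoromethyl-bearing group entering, though the groups exchanged are not the same as there, so that step is only a partial guide. Compound 2, carrying two trifluoromethyl groups, gives -26.9%, the lowest number. A downward step in this assay is therefore expected, a number 24.6 percentage points lower from compound 3 to compound 4 (beyond the scatter). Compound 4 is estimated at -5%, with a range from -30% to 15%.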

Compound 4, a percentage reported as activity, at one concentration (the size of the read-out at that concentration, not a potency): 13.2%
Estimate against measurement, compound 4: 18.2 percentage points below; measured number inside the range.
By their numbers in this assay, from the lowest: compound 2; then compound 1; then compounds 4 and 3 (each within the scatter of the next).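

In this assay, the change at this amide-type nitrogen gives a number 6.4 percentage points lower from compound 3 to compound 4 (within the scatter), so a single trifluoromethyl on the phenyl ring reads much like the two chloro groups it replaces. The larger shifts come from removing the second group beside a retained trifluoromethyl: hydrogen in place of trifluoromethyl gives a number 40.1 percentage points higher from compound 2 to compound 4 (beyond the scatter), and hydrogen in place of chloro gives a number 18 percentage points higher from compound 1 to compound 4 (beyond the scatter), so among these trifluoromethyl compounds a second group goes with a stronger effect, while compound 3 goes against any rule that two groups alone are enough. Nothing measured here accounts for these shifts.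

The compounds shown leave open whether a second group of another kind on this phenyl ring, such as a nitrile or an amine, would also lower the number. They also leave open how a phenyl ring with no groups at all, or one carrying a single chloro, would read.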